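The source may report more compounds than this note shows. Statements on the series, on what has been measured and on what is new or still open speak of the compounds shown alone.

Three compounds have been examined in an ADME assay on U-87MG ATCC cells for inhibition, with U-87 MG (Homo sapiens) as the target, read by MTT assay; a lower number here means that less compound is tolerated, a higher number that more compound is tolerated. Compound 1 `O=C(NCC1CCNCC1)c1c[nH]c2cc(-c3ccc(CN4CCCCC4)cc3)ccc12` reaches only a limit of the assay, reported as > 10000 nM. Compound 2 `O=C(NC1CCNCC1)c1c[nH]c2cc(-c3ccncc3)ccc12` likewise shows only a limit, > 10000 nM. Compound 3 `O=C(NCC1CCNCC1)c1cc2ccc(-c3ccc(OC(F)(F)F)cc3)cc2[nH]1` also sits at a limit, > 10000 nM. Compound 3 therefore stands at the limit of > 10000 nM in this assay, at which 3 of the 3 values shown sit, with no number of its own to compare. Compound 4 `O=C(NCC1CCNCC1)c1cc2ccc(-c3ccc(Oc4ccccc4)cc3)cc2[nH]1` differs from compound 3 by phenyl in place of trifluoromethyl on an oxygen on an aromatic ring. Among the compounds with values here, no step between measured compounds is available here, so the size of this change cannot be read from the data; the expectation is for no step beyond the scatter, with compound 4 again at the limit. The expected step from compound 3 to compound 4 is a step that the limit leaves unreadable from compound 3 to compound 4. Compound 4 is estimated at 15000 nM, within 7000 nM to 40000 nM.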

Compound 4, half-maximal cytotoxic concentration: > 10000 nM
Compound 4 gave a limit, no number; the forecaster's own chance of this, stated with the estimate: 80%; the middle value does not contradict the limit.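

Within the data shown here, compound 4, like compound 3, gives only a limit, so no step between compound 3 and compound 4 can be read: the limit of > 10000 nM in this assay, at which 4 of the 4 values shown sit. The compounds shown leave open what change to the shared core would bring a readable value in this assay.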